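The compounds below may be only part of what the source reports. "The series", "measured", "known", "first", "only" and "open" are said of these compounds alone.

Three dibenzoylhydrazines sharing one core have been examined in an assay on cells for agonist activity at ecdysone receptor (Bombyx mori), read by a luciferase reporter, with a stated time of 24 h; on this read-out higher numbers stand for an effect only at larger amounts of compound and lower numbers for an effect already at smaller amounts. Compound 1 `CC(C)(C)N(NC(=O)c1ccccc1Br)C(=O)c1ccccc1Cl` gives 316 nM. Compound 2 `CC(C)(C)N(NC(=O)c1cccc(F)c1)C(=O)c1ccccc1Cl` gives 69.2 nM, and compound 3 `Cc1cccc(C(=O)NN(C(=O)c2ccccc2Cl)C(C)(C)C)c1` gives 603 nM. Compound 3 thus has the highest number of the three: the step of a 1.9-fold higher number from compound 1 to compound 3 (0.28 log units; within the scatter) stays within the scatter, whereas the step of an 8.7-fold higher number from compound 2 to compound 3 (0.94 log units; beyond the scatter) lies beyond it, as does the step of a 4.6-fold lower number from compound 1 to compound 2 (0.66 log units; beyond the scatter).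

Compound 4 `Cc1ccc(C(=O)NN(C(=O)c2ccccc2Cl)C(C)(C)C)cc1` is not yet measured. It differs from compound 3 in one place: 4-methylphenyl in place of 3-methylphenyl on a carbonyl carbon. Among the compounds with values here, none of the measured steps moves a methyl within the ring; the steps from compound 1 to compound 2 and from compound 2 to compound 3 change the identity of the ring substituent, and the step from compound 1 to compound 3 is within the scatter. The data therefore give no firm direction for this change, and no step beyond the scatter is expected in this assay. The estimated step of a 1.1-fold lower number from compound 3 to compound 4 (0.04 log units; within the scatter) is expected to be small. Compound 4 is accordingly expected at 550 nM, with a range from 150 nM to 2000 nM.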

Compound 4, half-maximal effective concentration: 18.6 nM
Estimate against measurement, compound 4: 30-fold (1.47 log units) above; the whole stated range lies above it.
By their numbers in this assay, from the lowest: compound 4; then compound 2; then compounds 1 and 3 (each within the scatter of the next).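

In this assay the shift from 3-methylphenyl to 4-methylphenyl on the carbonyl carbon gives a 32-fold lower number from compound 3 to compound 4 (1.51 log units; beyond the scatter) with no change in atoms, so at this place the position of the methyl on the ring matters a great deal, which the earlier changes of substituent did not show. The 4-methylphenyl also stands below the other groups tried here, with a 3.7-fold lower number from compound 2 to compound 4 (0.57 log units; beyond the scatter) against the 3-fluorophenyl and a 17-fold lower number from compound 1 to compound 4 (1.23 log units; beyond the scatter) against the 2-bromophenyl, making compound 4 the lowest of the four. Nothing available explains why moving one methyl has so large an effect.

On these data alone, whether an ethyl group, a longer chain or an amine in place of the methyl of the 4-methylphenyl would keep the number this low stays open. So does whether the same gain from moving the methyl would appear with a different group on the other carbonyl.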